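The source may report more compounds than this note shows. Statements on the series, on what has been measured and on what is new or still open speak of the compounds shown alone.

Measured so far:
compound 1, `C/C=C1/[C@H](O[C@@H]2O[C@H](CO)[C@@H](O)[C@H](O)[C@H]2O)OC=C(C(=O)OC)[C@H]1CC(=O)OC`: > 15000 nM
compound 2, `C/C=C1/[C@H](O[C@@H]2O[C@H](COC(C)=O)[C@@H](OC(C)=O)[C@H](OC(C)=O)[C@H]2OC(C)=O)OC=C(C(=O)O)[C@H]1CC(=O)O`: > 20000 nM

Both values come from a functional assay on SK-BR-3 cells (Homo sapiens) for antiproliferative activity, read by MTT assay, with a stated time of 72 h; on this read-out lower numbers stand for stronger inhibition and higher numbers for weaker inhibition. For compound 1 the value > 15000 nM is a limit of the assay, not a number, as in the limit of > 15000 nM in this assay, at which 1 of the 2 values shown sits. For compound 2 the value > 20000 nM is likewise a limit, as in the limit of > 20000 nM in this assay, at which 1 of the 2 values shown sits. Within the data shown here, compound 1 therefore stands at a limit, and no step between measured compounds can be read. Compound 3, `C/C=C1/[C@H](O[C@@H]2O[C@H](CO)[C@@H](O)[C@H](O)[C@H]2O)OC=C(C(=O)OC)[C@H]1CC(=O)OCCc1ccccc1`, differs from compound 1 by benzyl in place of hydrogen on a saturated chain carbon bound to an oxygen next to a carbonyl group. With nothing measured to lean on, the change from compound 1 to compound 3 in this assay is expected to be small, in either direction, likely none beyond the scatter. Compound 3 is estimated at 20000 nM, within 5000 nM to 60000 nM, a step that the limit leaves unreadable from compound 1 to compound 3.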

Compound 3, half-maximal inhibitory concentration: 11000 nM
Compound 3: middle estimate off by 1.8-fold (0.26 log units), on the high side; the measured number falls inside the stated range.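

In this assay, among these compounds, compound 3 gives 11000 nM as the first measured number of the series, and an at least 1.3-fold lower number from compound 1 to compound 3 (0.13 log units; that floor lies within the scatter) is the step for methoxycarbonyl to phenethyloxycarbonyl. For compound 1 the value > 15000 nM is a limit of the assay, so the true size of this step cannot be read. The position therefore carries phenethyl and still gives a number, but nothing yet shows a real gain.

Going by these compounds, whether the ring or the chain matters stays open, since no plain propyl chain sits here for comparison. An amine on this chain also remains untested in the compounds shown.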